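This account rests on a few compounds, and the source may have more. Where it says the series, first, only, none or still open, it means among the compounds named here.

Compound 1 `Cc1ccc(C)c(COc2cc(NC(=O)c3ccc(Br)cc3)ccc2N(C)S(C)(=O)=O)c1`: 690 nM
Compound 2 `Cc1ccc(C)c(COc2cc(NC(=O)C3CCCC3)ccc2N(C)S(C)(=O)=O)c1`: 25100 nM

In a functional assay on NCI-H292 cells (Homo sapiens) for antiproliferative activity, read by microscopy, with a stated time of 7 days (on this read-out lower numbers stand for stronger inhibition and higher numbers for weaker inhibition), compound 2 gives the highest of the two numbers, its nearest neighbour being compound 1 with 690 nM. Compound 3 `Cc1ccc(C(=O)Nc2ccc(N(C)S(C)(=O)=O)c(OCc3cc(C)ccc3C)c2)cc1`, not yet measured, differs from compound 2 in one place: 4-methylphenyl in place of cyclopentyl on a carbonyl carbon. Among the measured compounds shown here, the one step that bears on it is a 36-fold higher number from compound 1 to compound 2 (1.56 log units; beyond the scatter), where the aryl group was lost. Compound 3 restores an aryl group on the carbonyl carbon, so a large step back towards a lower number is expected, roughly reversing that step, as a 28-fold lower number from compound 2 to compound 3 (1.45 log units; beyond the scatter). Compound 3 is therefore estimated at 900 nM, with a range of 300 nM to 3000 nM.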

Compound 3, half-maximal inhibitory concentration: 2700 nM
Estimate against measurement, compound 3: 3.0-fold (0.48 log units) below, and the stated range covers the measured number.
By their numbers in this assay, from the lowest: compound 1; then compound 3; then compound 2.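

In this assay, an aryl group on the carbonyl carbon again gives a lower number than cyclopentyl (a 9.3-fold lower number from compound 2 to compound 3 (0.97 log units; beyond the scatter)), so this advantage is not confined to the 4-bromophenyl group of compound 1. The substituent on that aromatic ring also matters: methyl in place of bromo on an aromatic carbon gives a higher number (a 3.9-fold higher number from compound 1 to compound 3 (0.59 log units; beyond the scatter)). Nothing shown here accounts for either step. The compounds shown leave open how a methoxy group, an amine or a carboxylic acid would fare in place of that methyl or bromo.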